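Oxadiazole to its oxide on a dihydropyridine aryl ether

The source may hold more compounds than are shown below. What is called first, only, known or untested is meant among the compounds shown, and "the series" means these compounds.

Compound 1 `COC(=O)C1=C(C)N=C(C)/C(=C(\O)OC)C1c1cccc([N+](=O)[O-])c1`: 1.2 nM
Compound 2 `COC(=O)C1=C(C)N=C(C)/C(=C(/O)OC)C1c1ccccc1OCCO[N+](=O)[O-]`: 38 nM
Compound 3 `COC(=O)C1=C(C)N=C(C)/C(=C(/O)OC)C1c1cccc(OCc2nonc2C)c1`: 320 nM

In an assay on Cortex for displacement of a labelled ligand from Voltage-dependent L-type calcium channel subunit alpha-1D (Rattus norvegicus) (a higher number here means a weaker inhibitor, a lower number a stronger inhibitor), compound 3 gives the highest number of the three, beyond the scatter from compound 2 and further still from compound 1, so it is the weakest inhibitor of the measured set. Compound 4 `COC(=O)C1=C(C)N=C(C)/C(=C(/O)OC)C1c1cccc(OCc2no[n+]([O-])c2C)c1` differs from compound 3 in one place: a group of 7 heavy atoms (3 carbon, 2 nitrogen, 2 oxygen; one five-membered aromatic ring with 3 hetero atoms) in place of a group of 6 heavy atoms (3 carbon, 2 nitrogen, 1 oxygen; one five-membered aromatic ring with 3 hetero atoms), on a saturated chain carbon bound to an oxygen on an aromatic ring. Within the data shown here, no single-point step between measured compounds is available to calibrate this change, so the expectation rests on compound 3 alone. The step from compound 3 to compound 4 is expected to be a 1.3-fold higher number from compound 3 to compound 4 (0.10 log units; within the scatter), not beyond the scatter in either direction. Compound 4 is therefore estimated at 400 nM in this assay, with a range from 150 nM to 1100 nM.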

Compound 4, inhibition constant: 370 nM
Beside the measured number, compound 4's estimate is 1.1-fold (0.03 log units) above it; low and high end bracket the measured number.
By their numbers in this assay, from the lowest: compound 1; then compound 2; then compounds 3 and 4 (each within the scatter of the next).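

In this assay, among these compounds, the first single-place comparison in the set reads a 1.2-fold higher number from compound 3 to compound 4 (0.06 log units; within the scatter) and so stays within the scatter. At this position, on a saturated chain carbon bound to an oxygen on an aromatic ring, the 4-methyl-1,2,5-oxadiazol-3-yl group and its oxide cannot be told apart in this assay. Nothing available bears on why the two compounds match. The compounds shown leave open whether an amine or a carboxylic acid in place of this ring would move the number beyond the scatter. They also leave open whether a longer chain carrying the same ring would do so.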